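The source may report more compounds than this note shows. Statements on the series, on what has been measured and on what is new or still open speak of the compounds shown alone.

Measured so far in a functional assay on HEK293 cells for antagonist activity at transient receptor potential cation channel subfamily V member 1 (Rattus norvegicus); on this read-out higher numbers stand for weaker inhibition and lower numbers for stronger inhibition:
compound 1, `CC(C)c1ccc(NC(=O)N2CCN(c3ncccc3[N+](=O)[O-])CC2)cc1`, gives 190 nM;
compound 2, `CC(C)c1ccc(NC(=O)N2CCN(c3ncccc3Br)CC2)cc1`, gives 4.6 nM;
compound 3, `O=C(Nc1ccc(Br)cc1)N1CCN(c2ncccc2Cl)CC1`, gives 491 nM.

Compound 2 and compound 1 differ in one place, (nitro in place of bromo on an aromatic carbon), and this change made a step of a 41-fold higher number from compound 2 to compound 1 (1.62 log units; beyond the scatter). Compound 3 shares the urea-piperazine framework with compound 2, but the difference between the two cores is not broken down here; its value stands highest of the three.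

Compound 4, `O=C(Nc1ccc([N+](=O)[O-])cc1)N1CCN(c2ncccc2Cl)CC1`, is not yet measured. It differs from compound 3 by nitro in place of bromo on an aromatic carbon. Among the measured compounds shown here, this is the same kind of change as the one from compound 2 to compound 1, but not the same: there the place was on a six-membered aromatic ring with 1 nitrogen, ortho to a large group, two atoms from the ring nitrogen, whereas here it is on a six-membered aromatic ring of carbon only, para to a large group.

In this assay a step of a 3.1-fold higher number from compound 3 to compound 4 (0.49 log units; beyond the scatter) is expected, smaller than the earlier one, because the earlier loss a 41-fold higher number from compound 2 to compound 1 (1.62 log units; beyond the scatter) was seen at a different place and compound 3 already starts weak. Compound 4 is therefore estimated at 1500 nM, between 400 nM and 6000 nM.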

Compound 4, half-maximal inhibitory concentration: 1110 nM
Beside the measured number, compound 4's estimate is 1.4-fold (0.13 log units) above it; the range from low to high includes it.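

In this assay nitro in place of bromo on an aromatic carbon gave a 2.3-fold higher number from compound 3 to compound 4 (0.35 log units; beyond the scatter) on the core of compound 3, a rise in the same direction as on the core of compound 2. The direction of the change carried from one core to the other, but its size did not: the same change on two cores in this assay, a 41-fold higher number (1.62 log units; beyond the scatter) from compound 2 to compound 1 and a 2.3-fold higher number (0.35 log units; beyond the scatter) from compound 3 to compound 4, 18-fold (1.26 log units) apart, beyond the scatter of two such steps. The change sits on a six-membered aromatic ring with 1 nitrogen in one pair and on a six-membered aromatic ring of carbon only in the other, and these two pairs do not show whether the gap follows the place of the change or the rest of the core.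

The compounds shown leave open how other groups in place of bromo, such as an amine or a carboxylic acid, would behave at either place. They also leave open what step the same change would give at one and the same place on two cores that differ only elsewhere.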